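Moving within the dimethylphenyl group of compound 2

A few compounds are considered here, and "the series" means these few. Any claim that something is new, unique, unknown or untested is made for them only; others in the source may bear on it.

Compound 2 `Cc1nc(-c2ccccc2)c(C(=O)N2CCN(c3cccc(C)c3C)CC2)o1` stands second highest of the three numbers in a toxicity assay on HUVEC cells (Homo sapiens) for inhibition; on this read-out lower numbers stand for stronger inhibition of growth and higher numbers for weaker inhibition of growth: nearest is compound 3 `Cc1nc(-c2cccc(F)c2)c(C(=O)N2CCN(c3cc(Cl)cc(Cl)c3)CC2)o1` with 0.134 ug/mL, furthest is compound 1 `Cc1nc(-c2ccccc2)c(C(=O)N2CCN(c3cccc(C#N)c3)CC2)o1` with 2.52 ug/mL, while compound 2 itself gives 0.38 ug/mL. Compound 4 `Cc1nc(-c2ccccc2)c(C(=O)N2CCN(c3ccc(C)c(C)c3)CC2)o1` is not yet measured. Its difference from compound 2 is 3,4-dimethylphenyl in place of 2,3-dimethylphenyl on an amine nitrogen in a ring. Of the measured steps only a 6.6-fold lower number from compound 1 to compound 2 (0.82 log units; beyond the scatter) concerns the same amine nitrogen in a ring, but it exchanges 3-cyanophenyl for 2,3-dimethylphenyl and so says nothing about exchanging 2,3-dimethylphenyl for 3,4-dimethylphenyl. Going by the values given here, compound 3 differs from compound 2 in more than one place, so its number gives no single step either. Among the compounds with values here, no step isolates the change at hand; the expectation is therefore a step in this assay that stays within the scatter, with no direction preferred. For compound 4 the expected value in this assay is 0.4 ug/mL, with a range from 0.15 ug/mL to 1.1 ug/mL. The expected step is a 1.1-fold higher number from compound 2 to compound 4 (0.02 log units; within the scatter).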

Compound 4, concentration for 50% growth inhibition: 3.52 ug/mL
The estimate for compound 4 lay 8.8-fold (0.94 log units) below the measured number; the measured number lies above the stated range.
By their numbers in this assay, from the lowest: compound 3; then compound 2; then compounds 1 and 4 (each within the scatter of the next).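

In this assay, the two dimethylphenyl groups have the same atoms joined differently, yet a 9.3-fold higher number from compound 2 to compound 4 (0.97 log units; beyond the scatter) shows that the amine nitrogen in a ring is sensitive to the arrangement of the methyl groups and not only to the kind of group placed there. With a 1.4-fold higher number from compound 1 to compound 4 (0.15 log units; within the scatter) as the other new step, 3,4-dimethylphenyl and 3-cyanophenyl cannot be told apart on this read-out, so among these compounds the lower number belongs to 2,3-dimethylphenyl and not to dimethylphenyl as such. No measurement at hand accounts for the difference between the two arrangements.

Open, from the compounds shown here alone, is whether 2-methylphenyl or 2,3-dichlorophenyl at this place would keep the lower number of compound 2. Also open, going by these compounds, is whether the same exchange gives a similar step with the 3-fluorophenyl group of compound 3 on the shared core.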